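Isopropoxy for Fluorodimethylphenoxy: One Swap, Seen Twice

The source may hold more compounds than are shown below. What is called first, only, known or untested is meant among the compounds shown, and "the series" means these compounds.

Of the compounds shown here, three from this series have been measured in a functional assay on MV4-11 cells (Homo sapiens) for antiproliferative activity, read by CCK-8 assay, with a stated time of 72 h; a higher number here means a weaker inhibitor, a lower number a stronger inhibitor. Compound 1, `CC(C)Oc1ccc(C(C)(C)O)cc1-c1cn(C)c(=O)c2[nH]c(C(=O)NCCCCCCC(=O)NO)cc12`, gives 160 nM. Compound 2, `Cc1cc(F)cc(C)c1Oc1ccc(C(C)(C)O)cc1-c1cn(C)c(=O)c2[nH]c(C(=O)NCc3ccc(C(=O)Nc4ccccc4N)cc3)cc12`, gives 240 nM. Compound 3, `Cc1cc(F)cc(C)c1Oc1ccc(C(C)(C)O)cc1-c1cn(C)c(=O)c2[nH]c(C(=O)NCCCCCCC(=O)NO)cc12`, gives 300 nM. All three values lie within the usual scatter of one another, so none of them can be set apart with confidence.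

Compound 3 and compound 1 differ in one place: isopropyl in place of 4-fluoro-2,6-dimethylphenyl on an oxygen on an aromatic ring. That change brought a 1.9-fold lower number from compound 3 to compound 1 (0.27 log units; within the scatter). Compound 2 and compound 3 differ in more than one place, and the difference between the two cores is not broken down here.

Compound 4, `CC(C)Oc1ccc(C(C)(C)O)cc1-c1cn(C)c(=O)c2[nH]c(C(=O)NCc3ccc(C(=O)Nc4ccccc4N)cc3)cc12`, has not yet been measured. It differs from compound 2 by isopropyl in place of 4-fluoro-2,6-dimethylphenyl on an oxygen on an aromatic ring. The place of this change reads word for word as it does for the pair of compound 3 and compound 1, so it is the same change, and among the compounds shown it occurs twice in all. Going by the values given here, only one measured instance exists, and it stayed within the scatter, so the expectation rests on a single observation. The expected step in this assay is a 1.5-fold lower number from compound 2 to compound 4 (0.18 log units; within the scatter), because the same change gave a 1.9-fold lower number from compound 3 to compound 1 (0.27 log units; within the scatter) and the earlier pair suggests little movement. Compound 4 is therefore estimated to give about 160 nM in this assay, with a plausible range from 80 nM to 320 nM.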

Compound 4, half-maximal inhibitory concentration: 40 nM
For compound 4 the middle estimate is 4.0-fold (0.60 log units) above the measured one; measured number outside the range, below it.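

In this assay, putting isopropyl in place of 4-fluoro-2,6-dimethylphenyl on the oxygen gave a 6.0-fold lower number from compound 2 to compound 4 (0.78 log units; beyond the scatter), a step that lies beyond the usual scatter. This shows that the size of the step seen on one core cannot simply be carried over to the other, and that a small step on one core does not rule out a much larger step on another: the same change on two cores in this assay, a 1.9-fold lower number (0.27 log units; within the scatter) from compound 3 to compound 1 and a 6.0-fold lower number (0.78 log units; beyond the scatter) from compound 2 to compound 4, 3.2-fold (0.51 log units) apart, beyond the scatter of two such steps. Going by these compounds alone, with only two pairs, this does not give a rule for any further core, it does not show which part of the rest of the molecule makes the two steps differ, and it cannot establish a shared direction, since the step on the first core stayed within the scatter.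

The compounds shown have only two groups on this oxygen, so it remains open how a methyl, an ethyl or a cyclopropylmethyl group there would compare on either core. On these data alone, it is also open how the swap would behave with a longer or shorter chain on the amide, which would help show whether the large step on the core of compound 2 is a special case or recurs elsewhere.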